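Removing a Methoxy Group on Two Related Cores

The compounds below may be only part of what the source reports. "The series", "measured", "known", "first", "only" and "open" are said of these compounds alone.

Compound 1 `COc1cc2oc(=O)cc(-c3ccc4c(ccn4C)c3)c2c(OC)c1OC`: 98 nM
Compound 2 `COc1cc(OC)c2c(-c3ccc4c(ccn4C)c3)cc(=O)oc2c1`: 73 nM
Compound 3 `COc1ccc(-c2cc(=O)oc3cc(OC)c(OC)c(OC)c23)cn1`: > 20000 nM

These three compounds were tested in an ADME assay on HBL-100 cells (Homo sapiens) for cytotoxicity, read by MTT assay, with a stated time of 72 h; on this read-out lower numbers stand for stronger inhibition and higher numbers for weaker inhibition. Compound 1 and compound 2 differ by hydrogen in place of methoxy on an aromatic carbon, and this change made a 1.3-fold lower number from compound 1 to compound 2 (0.13 log units; within the scatter). For compound 3 the assay reports only a limit, > 20000 nM, at which (the limit of > 20000 nM in this assay, at which 1 of the 3 values shown sits). The difference between the core of compound 1 and the core of compound 3 is not broken down here.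

Compound 4 `COc1ccc(-c2cc(=O)oc3cc(OC)c(OC)cc23)cn1` has not yet been measured in this assay. It differs from compound 3 by hydrogen in place of methoxy on an aromatic carbon. This is the same kind of change as that from compound 1 to compound 2, but not the same: there the position was ortho to two methoxy groups and meta and para to a fused ring, whereas here it is ortho to a fused ring and to one methoxy group, and meta to a fused ring and to a methoxy group. The earlier step stayed within the scatter, so compound 4 is expected to change little, meaning a step that the limit leaves unreadable from compound 3 to compound 4. Because compound 3 gives only a limit, > 20000 nM, compound 4 is also expected to reach only a limit. The estimate for compound 4 is 25000 nM, between 6000 nM and 80000 nM.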

Compound 4, half-maximal inhibitory concentration: 47000 nM
Compound 4: middle estimate off by 1.9-fold (0.27 log units), on the low side; measured number inside the range.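

The step from compound 3 to compound 4 cannot be read, because compound 3 has only a limit and not a number: the limit of > 20000 nM in this assay, at which 1 of the 4 values shown sits.

The compounds shown leave open whether hydrogen in place of methoxy has any real effect on the core of compound 3, where the same kind of change stayed within the scatter from compound 1 to compound 2.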